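A few compounds are considered here, and "the series" means these few. Any claim that something is new, unique, unknown or untested is made for them only; others in the source may bear on it.

Measured so far:
Compound 1, `COc1ccccc1NC(=O)c1ccnc2cc(Br)ccc12`: in a functional assay on KYSE-410 cells (Homo sapiens) for antiproliferative activity, read by MTT assay, with a stated time of 72 h (a lower number here means a stronger inhibitor, a higher number a weaker inhibitor), compound 1 gives > 20000 nM, which is a limit of the assay and not a number.
Compound 2, `O=C(Nc1cccc(Cl)c1)c1cc(=O)[nH]c2cc(Br)ccc12`: in this assay compound 2 gives > 20000 nM, also a limit.
Compound 3, `CC(C)(C)c1ccc(-c2ccc3c(C(=O)Nc4cccc(F)c4)cc(=O)[nH]c3c2)cc1`: in this assay compound 3 gives > 20000 nM, again a limit.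

Compound 3 therefore has no fixed place among the numbers shown. Its value is a limit, and so are the other two, so none of the three compounds can be put in order against another. The one thing the data establish is the limit of > 20000 nM in this assay, at which 3 of the 3 values shown sit. Within the data shown here, no measured pair differs in a single place, so there is no measured step from which the size of any change could be read.

Compound 4, `O=C(Nc1cccc(F)c1)c1cc(=O)[nH]c2cc(-c3ccc(F)c(CO)c3)ccc12`, is the compound not yet measured. It differs from compound 3 by 4-fluoro-3-(hydroxymethyl)phenyl in place of 4-(tert-butyl)phenyl on an aromatic carbon. With every measured value a limit, nothing here shows how large a step such a change makes, nor in which direction it would run. The expected outcome is an at least 1.1-fold lower number from compound 3 to compound 4 (0.04 log units; that floor lies within the scatter), that is, no step beyond the usual scatter. Compound 4 is accordingly estimated at 18000 nM, with a range from 4000 nM to 60000 nM, and it is expected that the assay will most likely again report only a limit.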

Compound 4, half-maximal inhibitory concentration: > 20000 nM
Compound 4: no number, only a limit (the forecaster's own chance of this, stated with the estimate: 65%); middle value at least 1.1-fold (0.04 log units) from the limit.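

In this assay compound 4 gives > 20000 nM, which is a limit of the assay and not a number. Compound 3 also gives only a limit, so the size of the change between compound 3 and compound 4 cannot be read. The compounds shown leave open how strongly any of them acts on these cells, and what any single change does, with every result at the same limit: the limit of > 20000 nM in this assay, at which 4 of the 4 values shown sit.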